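Ring substituent step from compound 1 to compound 3

The source may hold more compounds than are shown below. What is called first, only, known or untested is meant among the compounds shown, and "the series" means these compounds.

Measured in a functional assay on MCF7 cells (Homo sapiens) for cytotoxicity, read by MTT assay, with a stated time of 72 h, tested at 1 uM; on this read-out lower numbers stand for less inhibition of growth and higher numbers for more inhibition of growth at the one concentration tested:
- compound 1 `N/C(=N\NC(=S)N1CCCCCC1)c1ccccn1`: compound 1 gives 25.3%
- compound 2 `Cc1cccc(/C(N)=N/NC(=S)N2CCCCCC2)n1`: compound 2 gives 6.3%

Compound 1 stands highest of the two numbers; the nearest is compound 2, reached by a number 19 percentage points lower from compound 1 to compound 2 (beyond the scatter). Compound 3 `N/C(=N\NC(=S)N1CCCCCC1)c1ccc(F)cn1` differs from compound 1 by fluoro in place of hydrogen on an aromatic carbon. Among the compounds with values here, the only measured step, methyl for hydrogen on a different ring carbon, is of loose relevance; a group at a new place gives no firm direction. A step near the scatter, perhaps slightly downward, is expected: a number 5.3 percentage points lower from compound 1 to compound 3 (within the scatter). Compound 3 is estimated at 20%, range 5% to 35%.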

Compound 3, percent growth inhibition at one concentration: 16.8%
Beside the measured number, compound 3's estimate is 3.2 percentage points above it; the range from low to high includes it.
By their numbers in this assay, from the lowest: compound 2; then compounds 3 and 1 (each within the scatter of the next).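

In this assay the step of a number 8.5 percentage points lower from compound 1 to compound 3 (within the scatter) shows that fluoro in place of hydrogen, two atoms from the ring nitrogen and para to a large group, leaves the number within the scatter of compound 1. The step of a number 19 percentage points lower from compound 1 to compound 2 (beyond the scatter) involves another group at another ring carbon, so the two steps do not separate the effect of the group from that of its position. Nothing measured here offers an explanation for either step.

As far as these compounds go, it remains open whether methoxy or an amine at this position would move the number beyond the scatter. Also open, from the compounds shown here alone, is whether fluoro at the ring carbon bearing methyl in compound 2 would behave like that methyl.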